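Chalcone anilides: furan-2-yl for 4-methoxyphenyl, second instance

The compounds below may be only part of what the source reports. "The series", "measured", "known", "first", "only" and "open" are said of these compounds alone.

Compound 1 `COc1ccc(/C=C/C(=O)c2ccc(NC(=O)C(C)O[N+](=O)[O-])cc2)cc1` gives 43% in a functional assay on the whole organism (strain albino) for inhibition, with Rattus norvegicus as the target, read by paw edema, with stated times of 30 min and 1 h, at a dose of 100 mg/kg by the oral route; a lower number here means less inhibition, a higher number more inhibition at the dose given (going by the name of the read-out). Compound 2 `CC(O[N+](=O)[O-])C(=O)Nc1ccc(C(=O)/C=C/c2ccco2)cc1` gives 41% in this assay. Going by the values given here, the single change between them is furan-2-yl in place of 4-methoxyphenyl on a double-bonded chain carbon bound to a double-bonded chain carbon and it made the step of a number 2 percentage points lower from compound 1 to compound 2 (within the scatter). Compound 3 `COc1ccc(/C=C/C(=O)c2ccc(NC(=O)COc3ccc(/C(C)=N\O)cc3)cc2)cc1` gives 33% in this assay; the difference between its core and that of compound 1 is not broken down here, and the two values lie within the scatter of one another. Compound 4 `C/C(=N/O)c1ccc(OCC(=O)Nc2ccc(C(=O)/C=C/c3ccco3)cc2)cc1` is not yet measured. It differs from compound 3 by furan-2-yl in place of 4-methoxyphenyl on a double-bonded chain carbon bound to a double-bonded chain carbon, the same change already seen once from compound 1 to compound 2. The expected step of a number 2 percentage points lower from compound 3 to compound 4 (within the scatter) rests on that earlier step a number 2 percentage points lower from compound 1 to compound 2 (within the scatter), which stayed within the scatter. Compound 4 is therefore expected to give about 31%, estimated between 19% and 43%.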

Compound 4, a percentage reported as inhibition, in the whole organism at one dose (the size of the read-out at that dose, not a potency): 36%
Beside the measured number, compound 4's estimate is 5 percentage points below it; low and high end bracket the measured number.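

In this assay, furan-2-yl in place of 4-methoxyphenyl on a double-bonded chain carbon bound to a double-bonded chain carbon gives a step of a number 3 percentage points higher from compound 3 to compound 4 (within the scatter). Set beside the earlier instance, the change carries from one core to the other with no difference that can be told apart: the same change on two cores in this assay, a number 2 percentage points lower (within the scatter) from compound 1 to compound 2 and a number 3 percentage points higher (within the scatter) from compound 3 to compound 4, 5 percentage points apart, within the scatter of two such steps This shows only that the exchange leaves the read-out within the scatter on these two cores at a single dose; it does not show that the two groups are equal in potency, nor that the same would hold on any further core.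

Still open, on these data alone, is how a carboxylic acid or an amine would behave at this place. Also open, as far as these compounds go, is whether the two groups stay level at other doses.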